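Aryl thioether enones: DU-145 growth inhibition notes

The source may hold more compounds than are shown below. What is called first, only, known or untested is meant among the compounds shown, and "the series" means these compounds.

Measured compounds:
compound 1 `O=C(/C(=C\c1ccc(Cl)cc1)Sc1ccc(Br)cc1)c1ccc(Br)cc1` with 1000 nM
compound 2 `O=C(/C(=C\c1ccc(Cl)cc1)SCc1ccc(Cl)cc1)c1ccc(Br)cc1` with 10000 nM
compound 3 `Cc1ccc(CS/C(=C/c2ccc(F)c([N+](=O)[O-])c2)C(=O)c2ccc(C(=O)O)cc2)cc1` with 1000 nM

All three values come from a functional assay on DU-145 cells (Homo sapiens) for inhibition, read by trypan blue exclusion, with a stated time of 96 h; on this read-out lower numbers stand for stronger inhibition of growth and higher numbers for weaker inhibition of growth. Compound 2 gives the highest number of the three, with 10000 nM; compound 1 and compound 3 both sit a step below it, each beyond the scatter. Within the data shown here, the only single-point step among the measured compounds is the change on the sulfur, a 10-fold higher number from compound 1 to compound 2 (1.00 log units; beyond the scatter), which moved the number upward.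

Compound 4 `COc1ccccc1/C=C(/SCc1ccc(Cl)cc1)C(=O)c1ccc(Br)cc1` is not yet measured in this assay. It differs from compound 2 at a different site: 2-methoxyphenyl in place of 4-chlorophenyl on a double-bonded chain carbon bound to a double-bonded chain carbon. Among the measured compounds shown here, the one measured step concerns the group on the sulfur, not the aryl on the double-bonded chain carbon, so it does not bear on this change. Compound 3 carries a different aryl at that position, but it also differs from compound 2 in several further places. For that reason the value of compound 3, 1000 nM, cannot be read as a step. The data therefore give no basis for a direction; the expectation for compound 4 is a step of no change at the digits printed from compound 2 to compound 4 (within the scatter), within the scatter. Compound 4 is thus estimated at 10000 nM, in the range 3000 nM to 30000 nM.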

Compound 4, concentration for 50% growth inhibition: 1000 nM
The estimate for compound 4 lay 10-fold (1.00 log units) above the measured number; the whole stated range lies above it.
By their numbers in this assay, from the lowest: compounds 1, 3 and 4 (each within the scatter of the next); then compound 2.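

In this assay, the aryl on the double-bonded chain carbon proves to be a second site that moves the number: 2-methoxyphenyl in place of 4-chlorophenyl gives a 10-fold lower number from compound 2 to compound 4 (1.00 log units; beyond the scatter), whereas the earlier step spoke only to the group on the sulfur. The high number of compound 2 is therefore not set by the 4-chlorobenzyl group on the sulfur alone, since compound 4 keeps that group and gives 1000 nM. Nothing in the data accounts for this step.

Going by these compounds, the change swaps the substituent and its ring position in a single move, so it stays open whether the lower number goes with the methoxy group, with its ring position, or with the loss of the chlorine; 4-methoxyphenyl and 2-chlorophenyl at this carbon would separate these readings. On these data alone, it also stays open whether the same change would hold with 4-bromophenyl on the sulfur, and how an aminophenyl group at this carbon would compare.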